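Anilino-quinazoline thioethers: chloro added beside the fluoro

This account rests on a few compounds, and the source may have more. Where it says the series, first, only, none or still open, it means among the compounds named here.

Measured so far in a functional assay on PC-3 cells (Homo sapiens) for cytotoxicity, read by MTT assay, with a stated time of 72 h; on this read-out higher numbers stand for weaker inhibition and lower numbers for stronger inhibition:
compound 1 `COc1ccccc1Nc1nc(SCc2ccc(C(F)(F)F)cc2)nc2ccccc12` gives 14100 nM
compound 2 `FC(F)(F)c1ccc(CSc2nc(Nc3cccc(Br)c3)c3ccccc3n2)cc1` gives 8680 nM
compound 3 `Fc1ccc(Nc2nc(SCc3ccc(C(F)(F)F)cc3)nc3ccccc23)cc1` gives 7070 nM

All three share one core and differ only in the aryl group on the nitrogen. Compound 3 holds the lowest of the three numbers, but its separation from the others is small: the step of a 2.0-fold lower number from compound 1 to compound 3 (0.30 log units; within the scatter) and the step of a 1.2-fold lower number from compound 2 to compound 3 (0.09 log units; within the scatter) both lie within the scatter, as does a 1.6-fold lower number from compound 1 to compound 2 (0.21 log units; within the scatter). Across the three aryl groups tried, then, this assay shows no separation that can be trusted.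

Compound 4 `Fc1ccc(Nc2nc(SCc3ccc(C(F)(F)F)cc3)nc3ccccc23)cc1Cl` is the next step from compound 3: chloro in place of hydrogen on an aromatic carbon, placed ortho to the fluoro group and meta to the large group. Within the data shown here, none of the measured steps adds a substituent to an aryl ring already in place; each swaps one aryl for another, and each stays within the scatter. Nothing measured therefore points to a change beyond the scatter in this assay. The step of a 1.1-fold lower number from compound 3 to compound 4 (0.04 log units; within the scatter) is expected to be flat. Compound 4 is estimated at 6500 nM, with a range from 2500 nM to 16000 nM.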

Compound 4, half-maximal inhibitory concentration: 18600 nM
Beside the measured number, compound 4's estimate is 2.9-fold (0.46 log units) below it; measured number above the stated range.
By their numbers in this assay, from the lowest: compounds 3, 2, 1 and 4 (each within the scatter of the next, the first and the last beyond it).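

Unlike the aryl swaps among compounds 1, 2 and 3, adding chloro in place of hydrogen on an aromatic carbon, ortho to the fluoro group, gives a modest step beyond the scatter in this assay (a 2.6-fold higher number from compound 3 to compound 4 (0.42 log units; beyond the scatter)), towards weaker inhibition. The 3-chloro-4-fluorophenyl group also separates from the 3-bromophenyl group (a 2.1-fold higher number from compound 2 to compound 4 (0.33 log units; beyond the scatter)) but stays within the scatter of the 2-methoxyphenyl group (a 1.3-fold higher number from compound 1 to compound 4 (0.12 log units; within the scatter)), so this position responds to a single added atom, though only modestly. Nothing available here accounts for this rise.

Still open, on these data alone, is whether the rise belongs to chloro itself or would follow other groups at this place, such as a methyl or a nitrile. Also open, as far as these compounds go, is whether chloro would give the same step on a ring without the fluoro group.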